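Side-chain change on the amide of compound 2

The source may report more compounds than this note shows. Statements on the series, on what has been measured and on what is new or still open speak of the compounds shown alone.

Compound 1 `CC/C=C/C(=O)Nc1cc2c(N3CCc4ccccc43)ncnc2cc1O[C@@H]1CCOC1`, compound 2 `COc1cc2ncnc(N3CCCc4ccccc43)c2cc1NC(=O)C=C(C)C` and compound 3 `CC(C)=CC(=O)Nc1cc2c(N3CCCc4ccccc43)ncnc2cc1O[C@@H]1CCOC1` share one core and differ in the ether and in the acyl group on the amide nitrogen. In a functional assay on MCF7 cells (Homo sapiens) for antiproliferative activity, read by MTT assay, with a stated time of 72 h (on this read-out higher numbers stand for weaker inhibition and lower numbers for stronger inhibition), compound 2 gives 6870 nM, and compound 1 at 8840 nM and compound 3 at 11100 nM both sit within the scatter of it. Within the data shown here, the only single-point step measured, a 1.6-fold higher number from compound 2 to compound 3 (0.21 log units; within the scatter), concerns the ether, not the acyl group. Compound 4 `COc1cc2ncnc(N3CCCc4ccccc43)c2cc1NC(=O)/C=C/CN1CCCC1` differs from compound 2 by 3-(pyrrolidin-1-yl)prop-1-en-1-yl in place of 2-methylprop-1-en-1-yl on a carbonyl carbon. Among the measured compounds shown here, no measured step bears on this change, so a step in this assay of a 1.4-fold lower number from compound 2 to compound 4 (0.14 log units; within the scatter) is expected, within the scatter. Compound 4 is estimated at 5000 nM, with a range from 1500 nM to 17000 nM.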

Compound 4, half-maximal inhibitory concentration: 3190 nM
Compound 4: middle estimate off by 1.6-fold (0.20 log units), on the high side; the range from low to high includes it.
By their numbers in this assay, from the lowest: compound 4; then compounds 2, 1 and 3 (each within the scatter of the next).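

In this assay, among these compounds, the group on the carbonyl carbon gives the first step beyond the scatter in this set, though a modest one (a 2.2-fold lower number from compound 2 to compound 4 (0.33 log units; beyond the scatter)). Among the compounds shown here, the earlier step concerned only the ether, so this is the first reading at this position: 3-(pyrrolidin-1-yl)prop-1-en-1-yl is tolerated here in place of 2-methylprop-1-en-1-yl. No measured evidence bears on what lies behind this step.

Open, as far as these compounds go, is whether the step needs the pyrrolidine ring or would hold with an open-chain dimethylamino group or a longer chain. Also open, from the compounds shown here alone, is whether it carries over to the oxolan-3-yl ether of compound 3.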